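The source may hold more compounds than are shown below. What is called first, only, known or untested is meant among the compounds shown, and "the series" means these compounds.

Among the measured compounds shown here, compound 2 `CCSc1cc(C#N)cc(-c2ccc3ccc(C)nc3c2)c1` stands as the higher of the two numbers measured so far: in a functional assay on CHO cells for inhibition of metabotropic glutamate receptor 5 (Rattus norvegicus), read by FLIPR and calcium flux (on this read-out higher numbers stand for weaker inhibition and lower numbers for stronger inhibition), compound 2 gives 72 nM, while compound 1 `COCc1cc(C#N)cc(-c2ccc3ccc(C)nc3c2)c1` gives 2 nM, and the change from compound 1 to compound 2 brought a 36-fold higher number from compound 1 to compound 2 (1.56 log units; beyond the scatter). Compound 3 `CCS(=O)(=O)c1cc(C#N)cc(-c2ccc3ccc(C)nc3c2)c1` differs from compound 2 by ethylsulfonyl in place of ethylsulfanyl on an aromatic carbon. For the measured compounds named here, no measured step exchanges a sulfanyl for a sulfonyl, so the one known step offers only a rough guide. Compound 3 is therefore expected to show a 2.1-fold higher number from compound 2 to compound 3 (0.32 log units; beyond the scatter), a shift of uncertain size. Compound 3 is estimated at 150 nM, with a range from 30 nM to 800 nM.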

Compound 3, half-maximal inhibitory concentration: 1090 nM
For compound 3 the middle estimate is 7.3-fold (0.86 log units) below the measured one, outside the stated range (above it).
By their numbers in this assay, from the lowest: compound 1; then compound 2; then compound 3.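

Turning ethylsulfanyl into ethylsulfonyl keeps the ethyl chain and adds two oxygens on the sulfur, yet it gives a 15-fold higher number from compound 2 to compound 3 (1.18 log units; beyond the scatter) and so weakens inhibition far more. A change at the sulfur alone therefore matters greatly at this position, meta to a cyano group, and the full span so far is a 550-fold higher number from compound 1 to compound 3 (2.74 log units; beyond the scatter) for one group exchanged on the same core. Nothing available explains this loss. Going by these compounds, whether ethylsulfinyl, with one oxygen on the sulfur, or an amine here would lie nearer compound 1 or compound 3 remains open.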